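A chain-end ester in place of a methyl ether

The source may hold more compounds than are shown below. What is called first, only, known or untested is meant among the compounds shown, and "the series" means these compounds.

Compound 2 `COCCCCCCCCCCC/C=C1\CC(CO)(COC(=O)C(C)(C)C)OC1=O` carries a pivalate ester, a free hydroxymethyl group and a methoxy-terminated chain on the shared lactone core. In a functional assay on Hs-578T cells (Homo sapiens) for antiproliferative activity (on this read-out lower numbers stand for stronger inhibition of growth and higher numbers for weaker inhibition of growth), compound 2 gives 7.34 ug/mL. Among the values shown this is the only actual number; the one other value recorded is a limit. Compound 1 `CC(C)(C)C(=O)OCC1(CO)C/C(=C/CCCCCCCCCCCCCCC=O)C(=O)O1`, which ends its chain in an aldehyde, gives > 10 ug/mL in this assay, and that is a limit of the assay rather than a number. Since compound 1 sits at the limit of > 10 ug/mL in this assay, at which 1 of the 2 values shown sits, the two values allow no ordering of compound 1 against compound 2.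

Compound 3 `COC(=O)CCCCCCCCCCCCCC/C=C1\CC(CO)(COC(=O)C(C)(C)C)OC1=O` differs from compound 2 in a single place: 3-(methoxycarbonyl)propyl in place of methoxy on a saturated chain carbon, ten or more bonds along the chain from a double-bonded chain carbon. Among the measured compounds shown here, no measured pair in this set spans a change of this kind, so no step size can be read from the data. In this assay the step from compound 2 to compound 3 is expected to be small, at most a slight weakening and possibly none beyond the scatter, a 1.2-fold higher number from compound 2 to compound 3 (0.09 log units; within the scatter). Compound 3 is accordingly estimated at 9 ug/mL, with a range from 4 ug/mL to 20 ug/mL.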

Compound 3, concentration for 50% growth inhibition: > 10 ug/mL
Compound 3: only a limit was reported; the forecaster's own chance of this, stated with the estimate: 40%; middle value at least 1.1-fold (0.04 log units) from the limit.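

In this assay, among the compounds shown here, the exchange of methoxy for 3-(methoxycarbonyl)propyl on a saturated chain carbon gives the first step that can be read in this set, an at least 1.3-fold higher number from compound 2 to compound 3 (0.13 log units; that floor lies within the scatter). The value of compound 3 is a limit, so only the lower end of this step is fixed, and that floor alone does not show the change to weaken growth inhibition beyond the scatter. The change does show that this far end of the chain does not keep a measurable number once the methoxy gives way to the longer ester-bearing group, and the set now holds a second compound without one: the limit of > 10 ug/mL in this assay, at which 2 of the 3 values shown sit.

Going by these compounds, how far the number of compound 3 lies past the limit stays open, and so does whether the added chain length or the ester at its end accounts for the step. Also open, on these data alone, is whether a carboxylic acid or an amine at the chain end, or a shorter chain ending in the same methoxycarbonyl, would give a number inside the range of this assay.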